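Cytotoxicity notes on the side-chain change to compound 4

The source may hold more compounds than are shown below. What is called first, only, known or untested is meant among the compounds shown, and "the series" means these compounds.

In an ADME assay on cells (Homo sapiens) for cytotoxicity, read by polymerase chain reaction, with a stated time of 3 days (a higher number here means that more compound is tolerated, a lower number that less compound is tolerated), compound 1 `Nc1nc(Cl)c(-c2ccco2)c(N[C@@H]2C[C@H](CO)[C@@H](O)[C@H]2O)n1` reports only a limit, > 25000 nM. Compound 2 `CNc1nc(C)c(-c2nc3ccccc3s2)c(N[C@@H]2C[C@H](CO)[C@@H](O)[C@H]2O)n1` likewise reports a limit, > 25000 nM. Among the measured compounds shown here, compound 3 `COCCNc1nc(C)c(-c2nc3ccccc3s2)c(N[C@@H]2C[C@H](CO)[C@@H](O)[C@H]2O)n1` is the one member with a number, 21000 nM. Two of the three values sit at a limit (the limit of > 25000 nM in this assay, at which 2 of the 3 values shown sit). Compound 4 `Cc1nc(NCc2ccccc2)nc(N[C@@H]2C[C@H](CO)[C@@H](O)[C@H]2O)c1-c1nc2ccccc2s1` differs from compound 3 by phenyl in place of methoxymethyl on a saturated chain carbon bound to a nitrogen on an aromatic ring. For the measured compounds named here, no measured step covers that change itself; the only step seen on this chain, an at least 1.1-fold lower number from compound 2 to compound 3 (0.07 log units; that floor lies within the scatter), lies within the scatter, so no shift beyond the scatter is expected in this assay, in either direction. The estimated step is a 1.1-fold lower number from compound 3 to compound 4 (0.02 log units; within the scatter). Compound 4 is expected at 20000 nM, within 8000 nM to 50000 nM, with a fair chance that only a limit is reported.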

Compound 4, half-maximal cytotoxic concentration: 9000 nM
Compound 4: the middle estimate sits 2.2-fold (0.35 log units) above what was measured; low and high end bracket the measured number.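

On a saturated chain carbon bound to a nitrogen on an aromatic ring, phenyl in place of methoxymethyl gives a 2.3-fold lower number from compound 3 to compound 4 (0.37 log units; beyond the scatter) in this assay, which makes this change a real, though modest, shift on this chain. Phenyl in place of hydrogen at the same place gives an at least 2.7-fold lower number from compound 2 to compound 4 (0.44 log units; beyond the scatter). That second step is only a floor: the limit of > 25000 nM in this assay, at which 2 of the 4 values shown sit.

On these data alone, whether the shift needs an aromatic ring remains open, and cyclohexyl or pyridyl at this place would test that. As far as these compounds go, a longer chain carrying the phenyl also remains open.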